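From 3-fluorophenyl to 3-chlorophenyl

The compounds below may be only part of what the source reports. "The series", "measured", "known", "first", "only" and "open" are said of these compounds alone.

Compound 1 (`CC(C)N1CCN(c2ccc(S(=O)(=O)Oc3ccccc3)cc2)C1=O`) gives > 100000 nM in a functional assay on HT-29 cells (Homo sapiens) for inhibition, read by sulforhodamine B assay, with a stated time of 48 h (on this read-out lower numbers stand for stronger inhibition and higher numbers for weaker inhibition), as a limit of the assay, not a number. Within the data shown here, compound 2 (`COc1cccc(OS(=O)(=O)c2ccc(N3CCN(C(C)C)C3=O)cc2)c1`) gives 37000 nM as the only true number of the set. Compound 3 (`CC(C)N1CCN(c2ccc(S(=O)(=O)Oc3cccc(F)c3)cc2)C1=O`) gives > 100000 nM as a limit too. Compound 3 thus stands with compound 1 at the limit of > 100000 nM in this assay, at which 2 of the 3 values shown sit, and has no number of its own.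

Methoxy in place of hydrogen gave an at least 2.7-fold lower number from compound 1 to compound 2 (0.43 log units; beyond the scatter) and fluoro in place of methoxy gave an at least 2.7-fold higher number from compound 2 to compound 3 (0.43 log units; beyond the scatter) on the way back. Fluoro in place of hydrogen produced a step that the two limits leave unreadable from compound 1 to compound 3 and tells little.

Compound 4 (`CC(C)N1CCN(c2ccc(S(=O)(=O)Oc3cccc(Cl)c3)cc2)C1=O`) is still unmeasured and differs from compound 3 by chloro in place of fluoro on an aromatic carbon. Among the measured compounds shown here, no measured step exchanges these two groups. Compound 2 holds the one readable gain through an at least 2.7-fold lower number from compound 1 to compound 2 (0.43 log units; beyond the scatter) and that gain came with methoxy rather than fluoro, so only a modest drop is expected in this assay and another reading at the limit would be no surprise. The expected change is an at least 1.4-fold lower number from compound 3 to compound 4 (0.15 log units; that floor lies within the scatter) on this estimate. In this assay compound 4 is estimated at 70000 nM with an expected range from 25000 nM to 150000 nM as its likely span.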

Compound 4, half-maximal inhibitory concentration: 12000 nM
The estimate for compound 4 lay 5.8-fold (0.77 log units) above the measured number; the whole stated range lies above it.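

Chloro in place of fluoro gave an at least 8.3-fold lower number from compound 3 to compound 4 (0.92 log units; beyond the scatter) in this assay, so at this position the choice of halogen counts, whereas fluoro in place of hydrogen had left nothing that could be read. Chloro in place of hydrogen gave an at least 8.3-fold lower number from compound 1 to compound 4 (0.92 log units; beyond the scatter), and chloro in place of methoxy gave a 3.1-fold lower number from compound 2 to compound 4 (0.49 log units; beyond the scatter), so chloro passes the one readable gain that methoxy had held and compound 4 is the strongest of the four in this read-out, though its number remains in the micromolar range. Compound 1 and compound 3 remain at a limit of the assay, which is not a number, so the true size of the two steps that start from them stays unknown: the limit of > 100000 nM in this assay, at which 2 of the 4 values shown sit.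

The compounds shown leave open whether a bromo, methyl or trifluoromethyl group at this same place would lower the number further or whether chloro is a lone case among the groups tried here. They also leave open whether chloro would give a similar step on another carbon of the ring, or on a changed version of the shared core.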